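Amino in place of hydroxy: compound 3 to compound 4

A few compounds are considered here, and "the series" means these few. Any claim that something is new, unique, unknown or untested is made for them only; others in the source may bear on it.

Compound 1 `CCC(CC)[C@H](NC(C)=O)[C@@H]1[C@H](OC(=O)NCCCNC(=O)/C=C/c2ccc(O)c(O)c2)[C@@H](C(=O)O)C[C@H]1NC(=N)N`: > 100000 nM
Compound 2 `CCC(CC)[C@H](NC(C)=O)[C@@H]1[C@H](OC(=O)NCCCOCCCc2ccc(O)c(O)c2)[C@@H](C(=O)O)C[C@H]1NC(=N)N`: > 100000 nM
Compound 3 `CCC(CC)[C@H](NC(C)=O)[C@@H]1[C@H](OC(=O)NCCCO)[C@@H](C(=O)O)C[C@H]1NC(=N)N`: > 100000 nM

In an ADME assay on MDCK cells (Canis lupus familiaris) for cytotoxicity, with a stated time of 48 h (a lower number here means that less compound is tolerated, a higher number that more compound is tolerated), compound 3 gives > 100000 nM, which is a limit of the assay and not a number. The other two entries are limits as well, and what the set shows so far is the limit of > 100000 nM in this assay, at which 3 of the 3 values shown sit.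

Compound 4 `CCC(CC)[C@H](NC(C)=O)[C@@H]1[C@H](OC(=O)NCCCN)[C@@H](C(=O)O)C[C@H]1NC(=N)N` has not yet been measured. It differs from compound 3 by a single change, (amino in place of hydroxy on a saturated chain carbon, three bonds along the chain from an amide-type nitrogen). In words, this is amino in place of hydroxy on a saturated chain carbon, three bonds along the chain from an amide-type nitrogen.

Among the compounds with values here, the only measured step in the set is a step that the two limits leave unreadable from compound 2 to compound 3. That step removes a much larger group than the present swap touches, and it offers no size to carry over. Within the data shown here, no measured step shows a direction for this swap, so no step beyond the usual scatter is expected in this assay. The expectation rests on compound 3 at > 100000 nM, a limit.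

The expected step is a number no higher from compound 3 to compound 4 (the limit leaves the size open). The assay is expected most likely to report only a limit once more. The estimate for compound 4 is 100000 nM, with an expected range from 50000 nM to 200000 nM.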

Compound 4, half-maximal cytotoxic concentration: > 100000 nM
Compound 4 ended at the assay's limit (the forecaster's own chance of this, stated with the estimate: 90%); the middle value sits exactly at the limit.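

In this assay compound 4 gives > 100000 nM, which is a limit of the assay and not a number. Within the data shown here, compound 1, compound 2 and compound 3 also stand at a limit, so no step to compound 4 can be read. The compounds shown leave open how much compound the cells would tolerate beyond that limit, and whether amino in place of hydroxy changes this at all.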